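Anilino series: methoxyphenyl variant of compound 2

This account rests on a few compounds, and the source may have more. Where it says the series, first, only, none or still open, it means among the compounds named here.

Measured compounds:
- compound 1, `CCCc1ccc(NC2=CC(=O)c3nc4n(c3C2=O)[C@H]2OC[C@@H](O)[C@H]2OC4)cc1`, 1560 nM
- compound 2, `Cc1ccc(NC2=CC(=O)c3c(nc4n3[C@H]3OC[C@@H](O)[C@H]3OC4)C2=O)cc1C`, 1050 nM
- compound 3, `Cc1ccc(NC2=CC(=O)c3nc4n(c3C2=O)[C@H]2OC[C@@H](O)[C@H]2OC4)cc1`, 1420 nM

All three values come from a functional assay on MGC-803 cells (Homo sapiens) for inhibition, read by sulforhodamine B assay; on this read-out lower numbers stand for stronger inhibition and higher numbers for weaker inhibition. Compound 2 is not separated from the other two: its gap to compound 3 and its gap to compound 1 both lie within the scatter, so no order can be read among these three compounds.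

Going by the values given here, the one single-site step with both ends measured is a 1.1-fold lower number from compound 1 to compound 3 (0.04 log units; within the scatter). It shows that shortening the chain on the aryl ring of the anilino group leaves the number unchanged within the scatter. Compound 2 and compound 3 differ by one methyl on that ring; their two values are also within the scatter of each other.

Compound 4, `COc1cccc(NC2=CC(=O)c3c(nc4n3[C@H]3OC[C@@H](O)[C@H]3OC4)C2=O)c1`, is not yet measured in this assay. It carries the change (3-methoxyphenyl in place of 3,4-dimethylphenyl on an amine nitrogen). Among the compounds with values here, no measured step touches a methoxy group, so the only guide is that every substituent change on this ring so far has stayed within the scatter. Compound 4 is therefore expected to give 1200 nM, with a range from 600 nM to 2500 nM. The step of a 1.1-fold higher number from compound 2 to compound 4 (0.06 log units; within the scatter) is expected to stay within the scatter.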

Compound 4, half-maximal inhibitory concentration: 1790 nM
The estimate for compound 4 lay 1.5-fold (0.17 log units) below the measured number, and the stated range covers the measured number.
By their numbers in this assay, from the lowest: compounds 2, 3, 1 and 4 (each within the scatter of the next).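

In this assay, putting 3-methoxyphenyl in place of 3,4-dimethylphenyl on the amine nitrogen gives a 1.7-fold higher number from compound 2 to compound 4 (0.23 log units; within the scatter), with compound 2 at 1050 nM and compound 4 at 1790 nM. Until now, the only variation on this aryl group was in its carbon substituents; this step brings in an oxygen and a hydrogen-bond acceptor, yet the two values remain within the scatter of each other, so this exchange on the amine nitrogen does not separate the two compounds on this read-out. No measured information is available to account for the size of this step.

The step also combines two differences, the loss of both methyl groups and the gain of the methoxy group, so the share of each cannot be separated from compound 2 and compound 4 alone. Going by these compounds, it remains open whether a group of another kind on this aryl ring, such as a carboxylic acid or a dimethylamino group, would give a step beyond the scatter.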